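The source may hold more compounds than are shown below. What is called first, only, known or untested is meant among the compounds shown, and "the series" means these compounds.

Working notes on the series.

Three compounds share a core and have been run in a functional assay on the whole organism (strain Swiss) with Mus musculus as the target, in the maximal electroshock model, with a stated time of 1 h, at a dose of 300 mg/kg by the intraperitoneal route; on this read-out higher numbers stand for a stronger effect at the one dose given and lower numbers for a weaker effect. Compound 1, `CCC(C(=O)N1CCN(c2cccc(C)c2)CC1)N1C(=O)CCC1=O`, gives 75% in this assay. Compound 2, `CCC(C(=O)N1CCN(c2cccc(Cl)c2)CC1)N1C(=O)CCC1=O`, gives 100%. Compound 3, `Cc1cccc(N2CCN(C(=O)C(C)N3C(=O)CCC3=O)CC2)c1`, gives 0%, the lowest of the three numbers, and its gaps to compound 1 and to compound 2 both lie beyond the scatter.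

Two structural changes have been measured. The first is chloro in place of methyl on an aromatic carbon, and it made the step of a number 25 percentage points higher from compound 1 to compound 2 (beyond the scatter). The second is hydrogen in place of methyl on a saturated chain carbon, two bonds along the chain from an amide-type nitrogen in a ring and a carbonyl carbon, and it made the step of a number 75 percentage points lower from compound 1 to compound 3 (beyond the scatter).

Compound 4, `CC(C(=O)N1CCN(c2cccc(Cl)c2)CC1)N1C(=O)CCC1=O`, has not yet been measured in this assay. It differs from compound 3 by chloro in place of methyl on an aromatic carbon. The place lines of this change and of the change from compound 1 to compound 2 read the same word for word, so the change is the same one, made this time on the core of compound 3 rather than on the core of compound 1. How the two cores differ is the change from compound 1 to compound 3 given above.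

The change on the core of compound 1 gave a modest rise. On the core of compound 3, which starts from 0%, a rise of similar size would be expected at most, so a step of about a number 25 percentage points higher from compound 3 to compound 4 (beyond the scatter) is estimated for compound 4. The outcome for compound 4 is expected to be around 25%, with a range of 0% to 60%.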

Compound 4, a percentage reported as activity, at one dose (the size of the read-out at that dose, not a potency): 75%
Compound 4: middle estimate off by 50 percentage points, on the low side; the whole stated range lies below it.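

The new step is a number 75 percentage points higher from compound 3 to compound 4 (beyond the scatter), and in this assay it does not match the earlier step for chloro in place of methyl on an aromatic carbon: the same change on two cores in this assay, a number 25 percentage points higher (beyond the scatter) from compound 1 to compound 2 and a number 75 percentage points higher (beyond the scatter) from compound 3 to compound 4, 50 percentage points apart, beyond the scatter of two such steps. The change of hydrogen in place of methyl on the saturated chain carbon, now read with 3-chlorophenyl in place of 3-methylphenyl, gives a number 25 percentage points lower from compound 2 to compound 4 (beyond the scatter), and it too differs in size from the step on the other core: the same change on two cores in this assay, a number 75 percentage points lower (beyond the scatter) from compound 1 to compound 3 and a number 25 percentage points lower (beyond the scatter) from compound 2 to compound 4, 50 percentage points apart, beyond the scatter of two such steps. For the compounds shown here, each change therefore kept its direction across the two cores while its size did not carry over, so a step measured on one core is a poor guide to its size on the other; this rests on only two pairs of steps at a single dose, and it shows neither a potency nor the reason for the difference.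

From the compounds shown here alone, it remains open whether the same dependence on the core would appear with a trifluoromethyl or a methoxy group in place of the chloro on that aromatic carbon. Going by these compounds, it also remains open how a longer chain on the saturated chain carbon would behave with either 3-methylphenyl or 3-chlorophenyl in this assay.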